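The source may report more compounds than this note shows. Statements on the series, on what has been measured and on what is new or still open speak of the compounds shown alone.

Measured compounds, with values in an in vivo functional assay on the whole organism (MDA-MB-435 cells, Homo sapiens) for antiproliferative activity; a higher number here means a weaker inhibitor, a lower number a stronger inhibitor:

Compound 1, `CO[C@@H](C(=O)NC1CC[C@@H](OC(=O)C2CCCC2)CNC1=O)[C@H](O)[C@@H](O)[C@H](O)/C=C/C(C)(C)C`, in this assay gives 130 nM.
Compound 2, `CO[C@@H](C(=O)NC1CC[C@@H](OC(=O)CC2CCCCC2)CNC1=O)[C@H](O)[C@@H](O)[C@H](O)/C=C/C(C)(C)C`, in this assay gives 60 nM.
Compound 3, `CO[C@@H](C(=O)NC1CC[C@@H](OC(=O)C2CCCCC2)CNC1=O)[C@H](O)[C@@H](O)[C@H](O)/C=C/C(C)(C)C`, in this assay gives 4 nM.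

Compound 3 has the lowest number of the three and is the strongest inhibitor here, since both of its steps lie beyond the scatter: a 33-fold lower number from compound 1 to compound 3 (1.51 log units; beyond the scatter) and a 15-fold lower number from compound 2 to compound 3 (1.18 log units; beyond the scatter). Among the other two, a 2.2-fold lower number from compound 1 to compound 2 (0.34 log units; beyond the scatter).

Compound 4 is `CO[C@@H](C(=O)NC1CC[C@@H](OC(=O)C2CCCCCC2)CNC1=O)[C@H](O)[C@@H](O)[C@H](O)/C=C/C(C)(C)C`. The change from compound 3 is cycloheptyl in place of cyclohexyl on a carbonyl carbon.

For the measured compounds named here, no measured step adds one carbon to the ring itself. Going by the values given here, the steps that bear on it are the ring-size step, a 33-fold lower number from compound 1 to compound 3 (1.51 log units; beyond the scatter), and the step that adds one carbon outside the ring, a 15-fold lower number from compound 2 to compound 3 (1.18 log units; beyond the scatter). The first shows that enlarging the ring by one carbon gave a large gain; the second shows that one extra carbon placed differently gave a large loss. Widening the ring further is therefore expected to cost some potency rather than gain it, and the step from compound 3 to compound 4 is estimated as a 3.8-fold higher number from compound 3 to compound 4 (0.57 log units; beyond the scatter) in this assay.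

Compound 4 is expected to give about 15 nM, with a range from 3 nM to 80 nM.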

Compound 4, half-maximal inhibitory concentration: 20 nM
Compound 4: middle estimate off by 1.3-fold (0.12 log units), on the low side, and the stated range covers the measured number.
By their numbers in this assay, from the lowest: compound 3; then compound 4; then compound 2; then compound 1.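

Notes on the ring on the carbonyl carbon: in this assay, moving from cyclohexyl to cycloheptyl reverses the gain seen on enlarging cyclopentyl to cyclohexyl (a 5.0-fold higher number from compound 3 to compound 4 (0.70 log units; beyond the scatter)), so among the three rings shown, potency peaks at cyclohexyl and falls on either side of it. The loss on the larger side is only partial, since cycloheptyl still improves on cyclopentyl (a 6.5-fold lower number from compound 1 to compound 4 (0.81 log units; beyond the scatter)) and on cyclohexylmethyl (a 3.0-fold lower number from compound 2 to compound 4 (0.48 log units; beyond the scatter)); one carbon added to cyclohexyl therefore costs less when it sits within the ring than when it sits outside it. Nothing available here accounts for this ranking of the ring sizes.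

Still open, going by these compounds, is how this position responds to groups other than saturated carbon rings, such as a phenyl ring, a tert-butyl group, a longer straight alkyl chain, or a piperidine ring carrying an amine nitrogen. Also open, on these data alone, is whether cyclobutyl and cyclooctyl extend the same trend on either side of cyclohexyl, and whether the order of the four compounds holds in cell lines other than the one used here.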